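Hydroxypyridine amide variant of the benzoxazole carboxylic acid series

The compounds below may be only part of what the source reports. "The series", "measured", "known", "first", "only" and "open" are said of these compounds alone.

Measured so far:
compound 1 `O=C(Nc1c(O)cccc1-c1nc2c(C(=O)O)cccc2o1)c1cccnc1`: 240000 nM
compound 2 `COc1cccc(-c2nc3c(C(=O)O)cccc3o2)c1NC(=O)c1cc2ccccc2[nH]1`: 211000 nM

In an ADME assay on L6 cells (Rattus norvegicus) for cytotoxicity (on this read-out higher numbers stand for weaker inhibition and lower numbers for stronger inhibition), compound 1 gives 240000 nM and compound 2 gives 211000 nM; the two numbers lie within the usual scatter of each other, so neither stands apart. Compound 3 `O=C(Nc1c(O)cccc1-c1nc2c(C(=O)O)cccc2o1)c1ncccc1O` is not yet measured in this assay. It differs from compound 1 by 3-hydroxypyridin-2-yl in place of pyridin-3-yl on a carbonyl carbon. Within the data shown here, no measured pair tracks this change, so nothing in the numbers argues for a step beyond the scatter. Compound 3 is expected to give 230000 nM (range 110000 nM to 480000 nM). The expected step of a 1.0-fold lower number from compound 1 to compound 3 (0.02 log units; within the scatter) is estimated to stay within the scatter.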

Compound 3, half-maximal inhibitory concentration: 14200 nM
Estimate against measurement, compound 3: 16-fold (1.21 log units) above; the measured number lies below the stated range.
By their numbers in this assay, from the lowest: compound 3; then compounds 2 and 1 (each within the scatter of the next).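

In this assay the group on the carbonyl carbon is a sensitive place: 3-hydroxypyridin-2-yl in place of pyridin-3-yl gives a 17-fold lower number from compound 1 to compound 3 (1.23 log units; beyond the scatter), so this single change moves the series toward stronger inhibition of the L6 cells. Nothing at hand accounts for the size of this step.

The added hydroxyl and the changed attachment of the pyridine ring arrive together, so the step cannot yet be assigned to either. Plain pyridin-2-yl or 3-methoxypyridin-2-yl on the same carbonyl carbon would separate the two.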